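The source may report more compounds than this note shows. Statements on the series, on what has been measured and on what is new or still open speak of the compounds shown alone.

In a functional assay on SF-268 cells (Homo sapiens) for inhibition, read by sulforhodamine B assay, with a stated time of 48 h (on this read-out higher numbers stand for weaker inhibition of growth and lower numbers for stronger inhibition of growth), three compounds have been measured:
compound 1 `N#CCC1=NN=C(c2ccc(Br)cc2)C(CC(=O)c2ccc(Br)cc2)O1` gives 16900 nM;
compound 2 `N#CCC1=NN=C(c2ccc(Br)cc2)C(CC(=O)c2ccc([N+](=O)[O-])cc2)O1` gives 18500 nM;
compound 3 `N#CCC1=C(C#N)CC(c2ccc([N+](=O)[O-])cc2)=C(CC(=O)c2ccc([N+](=O)[O-])cc2)O1` gives 5 nM.

Compound 1 and compound 2 share one core and differ at a single place, (bromo in place of nitro on an aromatic carbon). That change produced a 1.1-fold lower number from compound 2 to compound 1 (0.04 log units; within the scatter). Compound 3 is built on another core; the difference between the two cores is not broken down here, and the number for compound 3 stands far lower than the numbers for compound 1 and compound 2.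

Compound 4 `N#CCC1=C(C#N)CC(c2ccc(Br)cc2)=C(CC(=O)c2ccc([N+](=O)[O-])cc2)O1` has not yet been measured in this assay. It differs from compound 3 by bromo in place of nitro on an aromatic carbon, the same change already seen from compound 2 to compound 1, at the same place on the ring. The earlier step was a 1.1-fold lower number from compound 2 to compound 1 (0.04 log units; within the scatter). On that basis the step to compound 4 is expected to be small, estimated at no change at the digits printed from compound 3 to compound 4 (within the scatter). Since this rests on a single pair on a different core, the expectation is held loosely. Compound 4 is therefore expected to give about 5 nM, between 1.5 nM and 17 nM.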

Compound 4, concentration for 50% growth inhibition: 3 nM
Compound 4: the middle estimate sits 1.7-fold (0.22 log units) above what was measured; measured number inside the range.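

In this assay bromo in place of nitro gave a 1.7-fold lower number from compound 3 to compound 4 (0.22 log units; within the scatter), so this swap of 4-nitrophenyl for 4-bromophenyl leaves compound 3 and compound 4 indistinguishable on this read-out. The change therefore carried from one core to the other with no step beyond the scatter on either, even though the numbers on the two cores stand far apart, and the two steps agree with each other: the same change on two cores in this assay, a 1.1-fold lower number (0.04 log units; within the scatter) from compound 2 to compound 1 and a 1.7-fold lower number (0.22 log units; within the scatter) from compound 3 to compound 4, 1.5-fold (0.18 log units) apart, within the scatter of two such steps. Among the compounds shown here, this shows only that the swap made no measurable difference in these two pairs; it does not show that the same would hold on a further core, and it says nothing about what separates the two cores, since neither step bears on that gap.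

The compounds shown leave open how an amine or a methoxy group would read at this place on the aromatic ring. They also leave open whether a carboxylic acid in place of a nitrile would keep the low numbers of compound 3 and compound 4.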